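Two Sugar Stereocentres Inverted on the Shared Core

The source may hold more compounds than are shown below. What is called first, only, known or untested is meant among the compounds shown, and "the series" means these compounds.

Compound 1 `C[C@@H]1O[C@H](N2C(=O)/C(=C3\Nc4ccccc4C3=O)c3ccccc32)[C@H](O)[C@H](O)[C@H]1O` in a functional assay on 5637 cells (Homo sapiens) for antiproliferative activity, read by crystal violet staining, with a stated time of 96 h (a higher number here means a weaker inhibitor, a lower number a stronger inhibitor), yields only a limit, > 12500 nM, not a number. Within the data shown here, compound 2 `O=C1/C(=C2/C(=O)N([C@@H]3O[C@H](CO)[C@H](O)[C@H](O)[C@H]3O)c3ccccc32)Nc2ccccc21` is the one compound here with a measured number, giving 24900 nM in this assay. Compound 3 `O=C1/C(=C2/C(=O)N([C@@H]3O[C@H](CO)[C@@H](O)[C@H](O)[C@@H]3O)c3ccccc32)Nc2ccccc21` keeps the same atoms and bonds as compound 2 and differs only in configuration: the two compounds have the same atoms and bonds and differ only in configuration as drawn: 2 of 6 stereo elements differ; a stereocentre at a saturated ring carbon is drawn R in compound 2 and S in compound 3; a stereocentre at a saturated ring carbon is drawn R in compound 2 and S in compound 3. Among the measured compounds shown here, no step between two measured compounds is available to guide this change. With nothing entering or leaving, the expected step in this assay, a 1.1-fold lower number from compound 2 to compound 3 (0.05 log units; within the scatter), is none beyond the usual scatter, in no firm direction. Compound 3 is therefore estimated at 22000 nM, with a range from 8000 nM to 60000 nM.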

Compound 3, half-maximal inhibitory concentration: 10600 nM
The estimate for compound 3 lay 2.1-fold (0.32 log units) above the measured number, and the stated range covers the measured number.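

In this assay, inverting two saturated ring carbons of the sugar gives a 2.3-fold lower number from compound 2 to compound 3 (0.37 log units; beyond the scatter), which shows that configuration alone can move the number beyond the scatter at this part of the molecule. The step can be assigned to stereochemistry alone, since nothing enters or leaves: the fact that compounds 2 and 3 differ only in the configuration as drawn Compound 1 offers only a limit, so no step can be read from it: the limit of > 12500 nM in this assay, at which 1 of the 3 values shown sits.

Which of the two inverted stereocentres carries the step remains open. So does whether an amine or a methoxy group in place of a sugar hydroxyl would shift the number.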